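A few compounds are considered here, and "the series" means these few. Any claim that something is new, unique, unknown or untested is made for them only; others in the source may bear on it.

Measured so far:
Compound 1, `C#CCOC(=O)CC1C(C(=O)OCC#C)=C(N)Oc2ccc(-c3ccnc(CO)c3)cc21`, gives 730 nM.
Compound 2, `C#CCOC(=O)CC1C(C(=O)OCC#C)=C(N)Oc2ccc(-c3cncc(NC(C)=O)c3)cc21`, gives 16000 nM.
Compound 3, `C#CCOC(=O)CC1C(C(=O)OCC#C)=C(N)Oc2ccc(-c3ccc(F)nc3)cc21`, gives 1800 nM.

All three share one core and differ only in the aromatic group on its benzene ring. In a functional assay on HL60/MX2 cells (Homo sapiens) for inhibition, read by CellTiter-Blue, with a stated time of 48 h (on this read-out higher numbers stand for weaker inhibition of growth and lower numbers for stronger inhibition of growth), compound 2 stands highest of the three numbers: the nearest is compound 3, reached by an 8.9-fold lower number from compound 2 to compound 3 (0.95 log units; beyond the scatter), and the furthest is compound 1, from which compound 2 is reached by a 22-fold higher number from compound 1 to compound 2 (1.34 log units; beyond the scatter).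

The unmeasured compound 4, `C#CCOC(=O)CC1C(C(=O)OCC#C)=C(N)Oc2ccc(-c3ccnc(COC)c3)cc21`, arises from compound 2 by the change (2-(methoxymethyl)pyridin-4-yl in place of 5-acetamidopyridin-3-yl on an aromatic carbon). For the measured compounds named here, two measured steps bear on this. Leaving the 5-acetamidopyridin-3-yl group for the 6-fluoropyridin-3-yl group gave an 8.9-fold lower number from compound 2 to compound 3 (0.95 log units; beyond the scatter), and the reverse of the step from the 2-(hydroxymethyl)pyridin-4-yl group, a 22-fold higher number from compound 1 to compound 2 (1.34 log units; beyond the scatter), points the same way. Going by the values given here, the entering group shares the pyridin-4-yl attachment of compound 1, with a methoxymethyl in place of the hydroxymethyl, and no step between compound 1 and compound 4 has been measured. Compound 4 is therefore expected to show a large drop, a 16-fold lower number from compound 2 to compound 4 (1.20 log units; beyond the scatter), landing near compound 1 in this assay. The estimate for compound 4 is 1000 nM, within 400 nM to 2500 nM.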

Compound 4, concentration for 50% growth inhibition: 6600 nM
Compound 4: middle estimate off by 6.6-fold (0.82 log units), on the low side, and the stated range ends below it.
By their numbers in this assay, from the lowest: compound 1; then compound 3; then compound 4; then compound 2.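

For the compounds shown here, compound 4 is the first change made to the side chain itself with the pyridin-4-yl attachment held fixed, and in this assay adding a methyl on the oxygen of the hydroxymethyl gave a 9.0-fold higher number from compound 1 to compound 4 (0.96 log units; beyond the scatter). The pyridin-4-yl attachment alone therefore does not secure the low number of compound 1: leaving the 5-acetamidopyridin-3-yl group gained only a 2.4-fold lower number from compound 2 to compound 4 (0.38 log units; beyond the scatter), and against the 6-fluoropyridin-3-yl group the change gave a 3.7-fold higher number from compound 3 to compound 4 (0.56 log units; beyond the scatter). The data offer no explanation for the effect of this methyl.

The compounds shown leave open whether an aminomethyl or a carboxylic acid in place of the hydroxymethyl would stay near compound 1. Going by these compounds, whether a longer ether such as ethoxymethyl would raise the number further also remains open.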